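This account rests on a few compounds, and the source may have more. Where it says the series, first, only, none or still open, it means among the compounds named here.

Measured so far:
compound 1 `Cc1cc(NC(=O)Nc2ccc(O)cc2)c2ccccc2n1` — 100 nM
compound 2 `Cc1cc(NC(=O)Nc2ccc(C(C)(C)C)cc2)c2ccccc2n1` — 6200 nM
compound 3 `Cc1cc(NC(=O)Nc2ccc(OC(F)(F)F)cc2)c2ccccc2n1` — 300 nM

In a physicochemical assay for solubility, at pH 7.4 (on this read-out lower numbers stand for lower solubility and higher numbers for higher solubility), compound 3 stands second highest of the three: a 3.0-fold higher number from compound 1 to compound 3 (0.48 log units; beyond the scatter) and a 21-fold lower number from compound 2 to compound 3 (1.32 log units; beyond the scatter). Compound 4 `Cc1cc(NC(=O)Nc2ccc(C(F)(F)F)cc2)c2ccccc2n1` is not yet measured; the change from compound 3 is trifluoromethyl in place of trifluoromethoxy on an aromatic carbon. Within the data shown here, no measured step covers this exact swap. Among the measured compounds shown here, the steps that bear on it, a 21-fold lower number from compound 2 to compound 3 (1.32 log units; beyond the scatter) and a 62-fold higher number from compound 1 to compound 2 (1.79 log units; beyond the scatter), were large but involve groups other than trifluoromethyl; the step of a 3.0-fold higher number from compound 1 to compound 3 (0.48 log units; beyond the scatter) was modest. For the measured compounds named here, with no directly comparable precedent, the expectation is a step within the scatter, a 1.2-fold higher number from compound 3 to compound 4 (0.07 log units; within the scatter). Compound 4 is therefore estimated at 350 nM in this assay, with a range from 120 nM to 1000 nM.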

Compound 4, solubility: 100 nM
Compound 4: the middle estimate sits 3.5-fold (0.54 log units) above what was measured; measured number below the stated range.
By their numbers in this assay, from the lowest: compounds 1 and 4 (each within the scatter of the next); then compound 3; then compound 2.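

In this assay the swap at this position is not neutral: losing the oxygen of trifluoromethoxy gives a measurable step (a 3.0-fold lower number from compound 3 to compound 4 (0.48 log units; beyond the scatter)). Trifluoromethyl cannot be told apart from hydroxy (no change at the digits printed from compound 1 to compound 4 (within the scatter)) and lies far from tert-butyl (a 62-fold lower number from compound 2 to compound 4 (1.79 log units; beyond the scatter)), so among these four groups only tert-butyl has a large step to every other compound. Nothing available explains these differences.

Still open, going by these compounds, is whether tert-butyl is a lone outlier or whether a branched group such as isopropyl or a basic amine at this position would give a similar step.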